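Methoxy to Bromo: Expected Effect on Vero Cell Toxicity

The source may hold more compounds than are shown below. What is called first, only, known or untested is meant among the compounds shown, and "the series" means these compounds.

Compound 1, `Cc1ccccc1C(=O)Nc1nc(-c2ccccn2)cs1`: 6300 nM
Compound 2, `COc1ccccc1C(=O)Nc1nc(-c2ccccn2)cs1`: 43500 nM

The two measured compounds share one core and differ in a single group on an aromatic carbon. In an ADME assay on Vero cells (Chlorocebus sabaeus) for cytotoxicity, read by MTT assay, with a stated time of 72 h (on this read-out higher numbers stand for an effect only at larger amounts of compound and lower numbers for an effect already at smaller amounts), compound 1 gives 6300 nM, while compound 2 gives 43500 nM; the step of a 6.9-fold higher number from compound 1 to compound 2 (0.84 log units; beyond the scatter) lies beyond the scatter. Compound 2 therefore stands at the highest of the two numbers, so its effect on the cells shows only at larger amounts than for compound 1.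

Compound 3, `O=C(Nc1nc(-c2ccccn2)cs1)c1ccccc1Br`, has not yet been measured. It differs from compound 2 by bromo in place of methoxy on an aromatic carbon. For the measured compounds named here, no measured step turns methoxy into bromo, so the only guide is that the methoxy compound, compound 2, sits well apart from compound 1 by the step of a 6.9-fold higher number from compound 1 to compound 2 (0.84 log units; beyond the scatter). Removing the methoxy may pull the number back toward that of compound 1, though the direction is not secured by any measured pair. A modest downward step is expected, a 2.9-fold lower number from compound 2 to compound 3 (0.46 log units; beyond the scatter). Compound 3 is expected to give roughly 15000 nM, with a range from 4000 nM to 60000 nM.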

Compound 3, half-maximal effective concentration: 3500 nM
For compound 3 the middle estimate is 4.3-fold (0.63 log units) above the measured one; the whole stated range lies above it.
By their numbers in this assay, from the lowest: compounds 3 and 1 (each within the scatter of the next); then compound 2.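

In this assay, this position on an aromatic carbon, ortho to a large group, responds strongly to the change of group: bromo in place of methoxy gives a 12-fold lower number from compound 2 to compound 3 (1.09 log units; beyond the scatter), a large step that takes away the high number seen with methoxy. Bromo in place of methyl gives a 1.8-fold lower number from compound 1 to compound 3 (0.26 log units; within the scatter), so compound 1 and compound 3 cannot be told apart here, and among these three groups methoxy alone stands apart, something the single earlier step between methyl and methoxy could not show. No measurement offered here explains why methoxy behaves differently from the other two groups.

Going by these compounds, with only methyl, methoxy and bromo to compare at this place, it remains open whether the higher number is special to methoxy or would also appear with other groups, such as an amine, a hydroxyl or a carboxylic acid, or with a longer chain like ethoxy. On these data alone, it is also open whether bromo in place of methoxy would give a step of similar size at another place on this ring, as all three compounds carry their group at the same place.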